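The compounds below may be only part of what the source reports. "The series", "measured", "known", "first", "only" and "open" are said of these compounds alone.

Compound 3 `O=C(Nc1ccc(-c2noc(-c3cccc(NS(=O)(=O)c4ccc(NC(=O)N5CCCCC5)cc4)c3)n2)c(Cl)c1)c1cccnc1` carries a ((piperidin-1-yl)carbonyl)amino group on the shared core. In a functional assay on MDA-MB-231 cells (Homo sapiens) for antiproliferative activity, read by MTT assay, with a stated time of 72 h (on this read-out higher numbers stand for weaker inhibition and lower numbers for stronger inhibition), compound 3 gives only a limit, > 10000 nM. Compound 1 `O=C(Nc1ccc(-c2noc(-c3cccc(NS(=O)(=O)c4ccccc4)c3)n2)c(Cl)c1)c1cccnc1` bears hydrogen at that aromatic carbon. In this assay compound 1 likewise gives only a limit, > 10000 nM. Among the compounds with values here, compound 2 `NC(=O)Nc1ccc(S(=O)(=O)Nc2cccc(-c3nc(-c4ccc(NC(=O)c5cccnc5)cc4Cl)no3)c2)cc1` carries a ureido group there, and in this assay compound 2 gives 2800 nM, the only plain number among the three. The step of an at least 3.5-fold lower number from compound 1 to compound 2 (0.55 log units; beyond the scatter) is at least modest, the step of an at least 3.5-fold higher number from compound 2 to compound 3 (0.55 log units; beyond the scatter) is at least modest in the other direction, and the step that the two limits leave unreadable from compound 1 to compound 3 cannot be read. Two of the three values sit at the limit of > 10000 nM in this assay, at which 2 of the 3 values shown sit, so compound 3 stands at the weak end of what is shown. Compound 4 `O=C(Nc1ccc(-c2noc(-c3cccc(NS(=O)(=O)c4ccc(NC(=O)N5CCOCC5)cc4)c3)n2)c(Cl)c1)c1cccnc1` differs from compound 3 by morpholin-4-yl in place of piperidin-1-yl on a carbonyl carbon. Within the data shown here, no measured step swaps one ring for another on that carbonyl carbon; the only measured change there, an at least 3.5-fold higher number from compound 2 to compound 3 (0.55 log units; beyond the scatter), runs toward weaker inhibition, and compound 3 already rests at the limit. Compound 4 is therefore expected to stay near that limit, with a number no higher from compound 3 to compound 4 (the limit leaves the size open) expected to be no step beyond the scatter. The estimate for compound 4 is 10000 nM, between 3000 nM and 30000 nM.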

Compound 4, half-maximal inhibitory concentration: > 10000 nM
Compound 4 gave a limit, no number (the forecaster's own chance of this, stated with the estimate: 60%); the middle value sits exactly at the limit.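

Putting morpholin-4-yl in place of amino on this carbonyl carbon gives an at least 3.5-fold higher number from compound 2 to compound 4 (0.55 log units; beyond the scatter) in this assay, so a ring with a second hetero atom brings back no plain number here, just as piperidin-1-yl did not. The steps joining compound 4 to compound 3 and to compound 1 cannot be read, since each has a limit at both ends. Among the compounds shown, only compound 2, with amino on that carbonyl carbon, gives a plain number, while both ring-bearing compounds sit with the unsubstituted compound 1 at the weak end: the limit of > 10000 nM in this assay, at which 3 of the 4 values shown sit.

On these data alone, whether a plain number survives with a small group on that carbonyl carbon, such as methylamino or dimethylamino, stays open. So does the effect of a ring with a free amine, such as piperazin-1-yl, at the same place.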